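Hydrazone series: methylation on oxygen versus on nitrogen

A few compounds are considered here, and "the series" means these few. Any claim that something is new, unique, unknown or untested is made for them only; others in the source may bear on it.

Measured compounds
compound 1 `COc1cc(/C=N/Nc2nc3ccccc3s2)cc(OC)c1O`: 36%
compound 2 `COc1cc(/C=N/N(C)c2nc3ccccc3s2)cc(OC)c1O`: 5%

In a physicochemical assay on cells (Homo sapiens), with a stated time of 18 h, tested at 1 uM (on this read-out lower numbers stand for a stronger effect and higher numbers for a weaker effect at the one concentration tested), compound 1 gives 36%, the higher of the two numbers shown, with compound 2 at 5%. Among the measured compounds shown here, the one measured step, a number 31 percentage points lower from compound 1 to compound 2 (beyond the scatter), is large and concerns methyl in place of hydrogen on a nitrogen on an aromatic ring. For the measured compounds named here, compound 3 `COc1cc(/C=N/Nc2nc3ccccc3s2)cc(OC)c1OC` differs from compound 1 by methyl in place of hydrogen on an oxygen on an aromatic ring, a change on an oxygen that no measured step covers. Going by the values given here, no step therefore bears directly on it, and the expectation is a step of a number 2 percentage points higher from compound 1 to compound 3 (within the scatter), not beyond the scatter, with a wide range. Compound 3 is estimated at 38%, between 12% and 70%.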

Compound 3, a percentage reported as activity, at one concentration (the size of the read-out at that concentration, not a potency): 100%
Compound 3: middle estimate off by 62 percentage points, on the low side; measured number outside the range, above it.
By their numbers in this assay, from the lowest: compound 2; then compound 1; then compound 3.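

In this assay, hydroxy to methoxy gives a number 64 percentage points higher from compound 1 to compound 3 (beyond the scatter) and shows that this position on the aromatic ring does not tolerate the change without a large shift in the read-out. Methyl in place of hydrogen on the nitrogen instead gives a number 31 percentage points lower from compound 1 to compound 2 (beyond the scatter) and runs the opposite way, so the outcome of methylation in these compounds depends on the atom that carries it. Nothing available accounts for the rise on the oxygen. Still open, on these data alone, is whether an amine or an ethoxy group in place of the hydroxy would behave like the hydroxy or like the methoxy. Also open, as far as these compounds go, is how methyl on both the oxygen and the nitrogen would read.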